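The source may report more compounds than this note shows. Statements on the series, on what has been measured and on what is new or still open speak of the compounds shown alone.

Compound 1, `O=C(COc1ccc2c(=O)ccoc2c1)Nc1cccc(NC(=O)c2ccc(F)cc2)c1`, gives 54 nM in an assay on isolated protein for inhibition of Rho-associated protein kinase 2 (Homo sapiens), read by scintillation counting, radiometric assay and 33P incorporation, with a stated time of 40 min, in the presence of a further agent that is not named here; on this read-out lower numbers stand for stronger inhibition and higher numbers for weaker inhibition.
Compound 2, `O=C(COc1ccc2c(=O)ccoc2c1)Nc1cccc(NC(=O)c2ccc(Br)cc2)c1`, gives 49 nM in this assay.
Compound 3, `CN(C)c1ccc(C(=O)Nc2cc(F)cc(NC(=O)COc3ccc4c(=O)ccoc4c3)c2)cc1`, gives 22 nM in this assay.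

Compounds 1 and 2 share one core and differ only in one place: bromo in place of fluoro on an aromatic carbon. In this assay this gave a 1.1-fold lower number from compound 1 to compound 2 (0.04 log units; within the scatter), so the two values show no difference that can be told from scatter. Compound 3 has a different core; how the core of compound 3 differs from that of compound 1 is not broken down here. Compound 3 gives the lowest of the three numbers, and its nearest neighbour is compound 2.

Compound 4, `CN(C)c1ccc(C(=O)Nc2cc(Br)cc(NC(=O)COc3ccc4c(=O)ccoc4c3)c2)cc1`, has not yet been measured in this assay. It differs from compound 3 in one place: bromo in place of fluoro on an aromatic carbon. This is the same kind of change as that from compound 1 to compound 2, but the surroundings are not identical: in compound 2 the bromo sits para to a large group, whereas in compound 4 it sits meta to two large groups. Since the earlier step was a 1.1-fold lower number from compound 1 to compound 2 (0.04 log units; within the scatter), the change is expected to move the value only a little on the core of compound 3 as well, and compound 4 is therefore expected to give a 1.1-fold lower number from compound 3 to compound 4 (0.04 log units; within the scatter). The estimate for compound 4 in this assay is 20 nM, expected to fall between 8 nM and 50 nM.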

Compound 4, half-maximal inhibitory concentration: 4560 nM
The estimate for compound 4 lay 230-fold (2.36 log units) below the measured number; measured number above the stated range.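

In this assay, bromo in place of fluoro on the core of compound 3 gave a 210-fold higher number from compound 3 to compound 4 (2.32 log units; beyond the scatter), a large loss of inhibition from a change that had left the values of compound 1 and compound 2 indistinguishable. The result of this change on one core therefore did not predict its result on the other in this series: the same change on two cores in this assay, a 1.1-fold lower number (0.04 log units; within the scatter) from compound 1 to compound 2 and a 210-fold higher number (2.32 log units; beyond the scatter) from compound 3 to compound 4, 230-fold (2.36 log units) apart, beyond the scatter of two such steps. These two pairs show that the change can be nearly silent on one core and severe on another, but they do not show which of the differences between the cores separates the two outcomes, nor whether the large step belongs to bromo as such or to bromo placed meta to two large groups.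

The compounds shown leave open how chloro, methyl or methoxy would behave at that same place on the core of compound 3, and so whether the values there rise gradually with the group or only bromo stands apart. They also leave open whether the dimethylamino group of compound 3 and compound 4 has any part in the outcome, which a pair carrying a halogen at that place but lacking the dimethylamino group could address.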